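A Halogen Swap on the Sulfonyl Aryl Group

The source may report more compounds than this note shows. Statements on the series, on what has been measured and on what is new or still open speak of the compounds shown alone.

In an assay on MDA-MB-231 cells for displacement of a labelled ligand from C-X-C chemokine receptor type 4 (Homo sapiens), read by fluorescence and microscopy, with stated times of 10 min and 30 min (on this read-out higher numbers stand for an effect only at larger amounts of compound and lower numbers for an effect already at smaller amounts), compound 2 `COc1ccccc1C(=O)NCc1ccc(CNS(=O)(=O)c2ccc(F)cc2)cc1` gives 100 nM, the lowest of the two numbers shown. Going by the values given here, compound 1 `COc1ccccc1C(=O)NCc1ccc(CNS(=O)(=O)c2cccc(C)c2)cc1` gives 1000 nM in this assay, and the only measured step, a 10-fold lower number from compound 1 to compound 2 (1.00 log units; beyond the scatter), shows that changing the aryl group on the sulfonyl sulfur can move the number well beyond the scatter. Compound 3 `COc1ccccc1C(=O)NCc1ccc(CNS(=O)(=O)c2ccccc2Cl)cc1` differs from compound 2 by 2-chlorophenyl in place of 4-fluorophenyl on a sulfonyl sulfur. Among the compounds with values here, no measured step involves a 2-chlorophenyl group, so the direction is open. Compound 3 is expected to show a 3.0-fold higher number from compound 2 to compound 3 (0.48 log units; beyond the scatter), a modest rise with wide uncertainty. The estimate for compound 3 is 300 nM, between 70 nM and 1500 nM.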

Compound 3, effective concentration (reported as EC, without a stated level of effect): 100 nM
Beside the measured number, compound 3's estimate is 3.0-fold (0.48 log units) above it; measured number inside the range.
By their numbers in this assay, from the lowest: compounds 2 and 3 (each within the scatter of the next); then compound 1.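

In this assay the change gives no change at the digits printed from compound 2 to compound 3 (within the scatter) and so leaves 2-chlorophenyl and 4-fluorophenyl on the sulfonyl sulfur level, even though the halogen and its ring position differ at once. The second halogen-bearing group also stands clear of the 3-methylphenyl compound, with a 10-fold lower number from compound 1 to compound 3 (1.00 log units; beyond the scatter) matching the earlier step in size. Nothing at hand bears on why these numbers fall as they do.

From the compounds shown here alone, whether 4-chlorophenyl or 2-fluorophenyl would match them stays open, so the halogen and its place cannot be separated. The compounds also leave open what a plain phenyl or a methoxyphenyl group would give.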